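Moving the Fluorine Around the Benzyl Ring

This account rests on a few compounds, and the source may have more. Where it says the series, first, only, none or still open, it means among the compounds named here.

Three compounds share one core and differ only in the group sitting on a saturated chain carbon bound to an aromatic nitrogen. Compound 1 `O=C(/C=C/c1ccc(OCc2cn(Cc3ccccc3Br)nn2)cc1)c1ccc([N+](=O)[O-])cc1` carries 2-bromophenyl there, compound 2 `O=C(/C=C/c1ccc(OCc2cn(Cc3cccc(Br)c3)nn2)cc1)c1ccc([N+](=O)[O-])cc1` carries 3-bromophenyl, and compound 3 `O=C(/C=C/c1ccc(OCc2cn(Cc3ccccc3F)nn2)cc1)c1ccc([N+](=O)[O-])cc1` carries 2-fluorophenyl. In a functional assay on A549 cells (Homo sapiens) for inhibition, read by MTT assay, with a stated time of 48 h, tested at 10 uM (on this read-out lower numbers stand for less inhibition of growth and higher numbers for more inhibition of growth at the one concentration tested), compound 1 gives 42%, compound 2 gives 28%, and compound 3 gives 43%. Compound 3 stands highest of the three numbers, but its gap to compound 1 is within the scatter a number 1 percentage points higher from compound 1 to compound 3 (within the scatter); only compound 2 sits clearly apart, as the step of a number 15 percentage points higher from compound 2 to compound 3 (beyond the scatter) shows.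

Compound 4 `O=C(/C=C/c1ccc(OCc2cn(Cc3cccc(F)c3)nn2)cc1)c1ccc([N+](=O)[O-])cc1` is the next step from compound 3: 3-fluorophenyl in place of 2-fluorophenyl on a saturated chain carbon bound to an aromatic nitrogen. The same move of a halogen from one position to another, with bromine instead of fluorine, is already measured: a number 14 percentage points lower from compound 1 to compound 2 (beyond the scatter), a modest loss. Since swapping bromine for fluorine in the same place changed little a number 1 percentage points higher from compound 1 to compound 3 (within the scatter), the position of the halogen appears to matter more than its identity, at least within these three compounds. A drop of similar size is therefore expected in this assay for compound 4, namely a number 13 percentage points lower from compound 3 to compound 4 (beyond the scatter). The estimate for compound 4 is 30%, with a range from 18% to 42%.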

Compound 4, percent growth inhibition at one concentration: 33%
Compound 4: the middle estimate sits 3 percentage points below what was measured, and the stated range covers the measured number.
By their numbers in this assay, from the lowest: compounds 2, 4, 1 and 3 (each within the scatter of the next, the first and the last beyond it).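

In this assay, moving the fluorine gives a step at the edge of what can be told apart, a number 10 percentage points lower from compound 3 to compound 4 (within the scatter), whereas the same move with bromine gave a step that could be told apart, a number 14 percentage points lower from compound 1 to compound 2 (beyond the scatter), so the loss seen with bromine is not clearly repeated with fluorine. Compound 4 also cannot be separated from either bromine compound, with a number 5 percentage points higher from compound 2 to compound 4 (within the scatter) and a number 9 percentage points lower from compound 1 to compound 4 (within the scatter), which leaves it in the middle of the group rather than alongside compound 2 alone. Fluoro in place of bromo can now be read twice, with 2-substituted and with 3-substituted rings, and it makes no clear difference in either case: the same change on two cores in this assay, a number 1 percentage points higher (within the scatter) from compound 1 to compound 3 and a number 5 percentage points higher (within the scatter) from compound 2 to compound 4, 4 percentage points apart, within the scatter of two such steps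

All four compounds carry a single halogen on this ring, so they cannot show whether the pattern extends beyond bromine and fluorine, or to a 4-fluorophenyl group. Going by these compounds, whether a ring carrying an amine, a methoxy group or a carboxylic acid in this place would give a clearly different growth inhibition also remains open.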